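Bromo added to compound 3 in the amide series

The compounds below may be only part of what the source reports. "The series", "measured", "known", "first", "only" and "open" are said of these compounds alone.

Compound 1 `O=C(Nc1cccc(Cl)c1)c1cccc(Br)c1`: a limit in an assay on isolated protein for inhibition of thiosulfate sulfurtransferase (Homo sapiens), with a stated time of 60 min, in the absence of a further agent (on this read-out lower numbers stand for stronger inhibition and higher numbers for weaker inhibition), > 100000 nM.
Compound 2 `O=C(Nc1cccc(Cl)c1)c1ccccc1O`: a limit in this assay, > 100000 nM.
Compound 3 `COc1ccccc1C(=O)Nc1cccc(Cl)c1`: a limit in this assay, > 100000 nM.

Going by the values given here, compound 3 stands at a limit, as do the two other compounds measured so far; no numbered value exists for any of them. Among the compounds with values here, the one measured step, a step that the two limits leave unreadable from compound 2 to compound 3, is unreadable because both of its compounds sit at the limit of > 100000 nM in this assay, at which 3 of the 3 values shown sit. Compound 4 `COc1ccc(Br)cc1C(=O)Nc1cccc(Cl)c1` differs from compound 3 by bromo in place of hydrogen on an aromatic carbon, the bromo entering on an aromatic carbon para to a methoxy group. No measured step bears on this change, so no direction can be taken from the compounds shown. Compound 4 is expected to give 100000 nM, between 30000 nM and 300000 nM. The step this estimate means, a number no higher from compound 3 to compound 4 (the limit leaves the size open), is expected to lie within the scatter, with a further limit being the most likely outcome.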

Compound 4, half-maximal inhibitory concentration: > 100000 nM
Compound 4 ended at the assay's limit; the forecaster's own chance of this, stated with the estimate: 70%; the middle value lies on the limit itself.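

No new step can be read for compound 4 against compound 3 or compound 1, because all of these compounds sit at one limit: the limit of > 100000 nM in this assay, at which 4 of the 4 values shown sit. The compounds shown leave open whether in this assay any change to the shared core would give a numbered value.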